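Aryl change on the sulfonyl of an inactive pair

The source may hold more compounds than are shown below. What is called first, only, known or untested is meant among the compounds shown, and "the series" means these compounds.

compound 1 `COc1ccc(-c2cc(=O)c3c(OC)cc(OC)cc3n2S(=O)(=O)c2ccc(F)cc2)cc1` in a functional assay on HepG2 cells (Homo sapiens) for antiproliferative activity, with a stated time of 72 h; a higher number here means that more compound is needed for the effect, a lower number that less compound is needed: > 65500 nM.
compound 2 `COc1ccc(-c2cc(=O)c3c(OC)cc(OC)cc3n2S(=O)(=O)c2ccc(Cl)cc2)cc1` in this assay: > 34400 nM.

For compound 1 the value > 65500 nM is a limit of the assay, not a number. For compound 2 the value > 34400 nM is likewise a limit. The step that the two limits leave unreadable from compound 1 to compound 2 is therefore unreadable in size and direction; all that is known are the two limits the limit of > 34400 nM in this assay, at which 1 of the 2 values shown sits, and (the limit of > 65500 nM in this assay, at which 1 of the 2 values shown sits). Compound 2 thus stands at a limit, with no readable number in this series.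

Compound 3 `COc1ccc(-c2cc(=O)c3c(OC)cc(OC)cc3n2S(=O)(=O)c2cc(Cl)cc(Cl)c2O)cc1` has not yet been measured in this assay. It carries 3,5-dichloro-2-hydroxyphenyl in place of 4-chlorophenyl on a sulfonyl sulfur. Going by the values given here, no measured step bears on this change, since the only step between measured compounds is unreadable. With both measured compounds at a limit, compound 3 is expected to return a limit again, and the step that the limit leaves unreadable from compound 2 to compound 3 is expected to be none beyond the scatter. For compound 3 the estimate in this assay is 40000 nM, with a range from 8000 nM to 120000 nM.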

Compound 3, half-maximal effective concentration: > 37900 nM
Compound 3: no number, only a limit (the forecaster's own chance of this, stated with the estimate: 70%); the middle value does not contradict the limit.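

In this assay compound 3 gives > 37900 nM, a limit and not a number. Going by these compounds alone, compound 1, compound 2 and compound 3 all stand at limits, and no step among them can be read. The compounds shown leave open whether any aryl group on the sulfonyl sulfur gives a readable value in this assay.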